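The source may hold more compounds than are shown below. What is called first, only, known or untested is meant among the compounds shown, and "the series" means these compounds.

Compound 1 `Cc1nc(S(C)(=O)=O)ccc1Oc1ncnc(OC2CCN(C(=O)OC3CCC3)CC2)c1F` gives 167 nM in a functional assay on isolated protein for inhibition of Glucose-dependent insulinotropic receptor (Rattus norvegicus), read by HTRF and cAMP accumulation; a higher number here means that more compound is needed for the effect, a lower number that less compound is needed. Compound 2 `Cc1nc(S(C)(=O)=O)ccc1Oc1ncnc(OC2CCN(C(=O)OC(C)(C)C#N)CC2)c1F` gives 1320 nM. Compound 3 `Cc1nc(S(C)(=O)=O)ccc1Oc1ncnc(OC2CCN(C(=O)SC3(C)CC3)CC2)c1F` gives 166 nM.

Among these three, compound 2 has the highest number; its nearest neighbour is compound 1, with a 7.9-fold higher number from compound 1 to compound 2 (0.90 log units; beyond the scatter), and compound 3 lies furthest, with an 8.0-fold lower number from compound 2 to compound 3 (0.90 log units; beyond the scatter). Compound 4 `Cc1nc(S(C)(=O)=O)ccc1Oc1ncnc(OC2CCN(C(=S)OC(C)C)CC2)c1F` has not been measured. It differs from compound 2 in this way: a group of 6 heavy atoms (4 carbon, 1 oxygen, 1 sulfur; no ring) in place of a group of 8 heavy atoms (5 carbon, 1 nitrogen, 2 oxygen; no ring), on an amine nitrogen in a ring. The two steps that bear on it are the ones leaving compound 2 for compound 1 and compound 3, both modest and both beyond the scatter, and both take the number down when the 1-cyano-1-methylethyl group is exchanged. Compound 4 is therefore expected to show a modestly lower number, about a 4.4-fold lower number from compound 2 to compound 4 (0.64 log units; beyond the scatter), with an estimate for compound 4 of 300 nM, ranging from 100 nM to 900 nM.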

Compound 4, half-maximal effective concentration: 1050 nM
Compound 4: the middle estimate sits 3.5-fold (0.54 log units) below what was measured, outside the stated range (above it).
By their numbers in this assay, from the lowest: compounds 3 and 1 (each within the scatter of the next); then compounds 4 and 2 (each within the scatter of the next).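

In this assay, losing the nitrile did not by itself bring the number down on the ring amine nitrogen (a 1.3-fold lower number from compound 2 to compound 4 (0.10 log units; within the scatter)). The ring-free group of compound 4 stayed clear of both ring-bearing groups (a 6.3-fold higher number from compound 3 to compound 4 (0.80 log units; beyond the scatter); a 6.3-fold higher number from compound 1 to compound 4 (0.80 log units; beyond the scatter)), so among these four compounds, the two low numbers go with a carbon ring in the group. No measurement here explains these differences. Compound 4 also carries its sulfur differently from compound 3, so the effects of ring and sulfur remain unseparated. As far as these compounds go, how an isopropoxycarbonyl group or a urea would fare on this nitrogen remains open.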